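Swapping the aryl substituent in a small lactone series

The source may hold more compounds than are shown below. What is called first, only, known or untested is meant among the compounds shown, and "the series" means these compounds.

Compound 2 `Cc1cccc(C[C@H]2C(=O)OC[C@@H]2Cc2ccccc2)c1` is tested in a functional assay on HL-60 cells (Homo sapiens) for cytotoxicity, read by WST assay, with a stated time of 48 h (a lower number here means that less compound is needed, a higher number that more compound is needed for the effect), and gives 53000 nM. Going by the values given here, its only neighbour, compound 1 `COc1cccc(C[C@H]2C(=O)OC[C@@H]2Cc2ccccc2)c1`, gives 66000 nM, and the two values lie within the usual scatter; the single measured step, a 1.2-fold lower number from compound 1 to compound 2 (0.10 log units; within the scatter), is small. Compound 3 `O=C1OC[C@H](Cc2ccccc2)[C@H]1Cc1ccc(F)cc1` carries a different aryl group: 4-fluorophenyl in place of 3-methylphenyl on a saturated chain carbon bound to a saturated ring carbon. Among the compounds with values here, the one measured step touched only a substituent on that same ring and changed little, so no step beyond the scatter is expected here either, with a 1.0-fold higher number from compound 2 to compound 3 (0.02 log units; within the scatter). Compound 3 is therefore estimated at 55000 nM, within 25000 nM to 120000 nM.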

Compound 3, half-maximal effective concentration: 57000 nM
Beside the measured number, compound 3's estimate is 1.0-fold (0.02 log units) below it, and the stated range covers the measured number.
By their numbers in this assay, from the lowest: compounds 2, 3 and 1 (each within the scatter of the next).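

Swapping the whole aryl group, rather than only a substituent on it, gives a 1.1-fold higher number from compound 2 to compound 3 (0.03 log units; within the scatter) in this assay. The earlier step changed methoxy to methyl on the ring, whereas this one exchanges 3-methylphenyl for 4-fluorophenyl on a saturated chain carbon bound to a saturated ring carbon, and this assay still cannot tell the two compounds apart. No measurement available here offers an explanation for how close these numbers are.

As far as these compounds go, whether an aryl ring carrying an amine or a carboxylic acid would give a step beyond the scatter remains open. So does the effect of a longer chain in place of the aryl group.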